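A few compounds are considered here, and "the series" means these few. Any claim that something is new, unique, unknown or untested is made for them only; others in the source may bear on it.

Compound 1 `CC(C)n1cnc2c(Nc3ccccc3)nc(NCOCc3ccc(C(=O)Nc4ccccc4N)cc3)nc21` is one of three purine-based amides measured in a functional assay on HCT-116 cells (Homo sapiens) for antiproliferative activity, read by CCK-8 assay, with a stated time of 72 h, tested at 2 uM (a higher number here means a stronger effect of the compound at the concentration tested, a lower number a weaker effect), where compound 1 gives 6.85%. Compound 2 `Nc1ccccc1NC(=O)/C=C/c1ccc(COCNc2nc(Nc3cccc(Cl)c3)c3ncn(C4CCCC4)c3n2)cc1` gives 9.04% in this assay, a value within the scatter of that of compound 1, and compound 3 `CC(C)n1cnc2c(Nc3cccc(Cl)c3)nc(NCOCc3ccc(/C=C/C(=O)Nc4ccccc4N)cc3)nc21` gives 18.5%, which lies beyond the scatter from compound 1. Compounds 3 and 2 differ only by cyclopentyl in place of isopropyl on an aromatic nitrogen, and this change gave a number 9.5 percentage points lower from compound 3 to compound 2 (within the scatter). Compound 4 `Nc1ccccc1NC(=O)c1ccc(COCNc2nc(Nc3ccccc3)c3ncn(C4CCCC4)c3n2)cc1` is not yet measured; it differs from compound 1 by cyclopentyl in place of isopropyl on an aromatic nitrogen, the same change at the same place. The difference between the cores of compound 1 and compound 3 is not broken down here. Resting on the step from compound 3 to compound 2 a number 9.5 percentage points lower from compound 3 to compound 2 (within the scatter), the step is expected to be a number 1.9 percentage points lower from compound 1 to compound 4 (within the scatter) for compound 4. Compound 4 is estimated at 5%, expected between 0% and 14%.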

Compound 4, a percentage reported as inhibition, at one concentration (the size of the read-out at that concentration, not a potency): 75.2%
Beside the measured number, compound 4's estimate is 70.2 percentage points below it; measured number outside the range, above it.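

Cyclopentyl in place of isopropyl on an aromatic nitrogen gave a number 68.4 percentage points higher from compound 1 to compound 4 (beyond the scatter) in this assay, and the step read on one core did not carry over to the other: the same change on two cores in this assay, a number 9.5 percentage points lower (within the scatter) from compound 3 to compound 2 and a number 68.4 percentage points higher (beyond the scatter) from compound 1 to compound 4, 77.8 percentage points apart, beyond the scatter of two such steps. In this series, then, the effect of this change depends on the core that carries it and cannot be treated as a fixed increment. These two pairs do not show which part of the difference between the cores is responsible, nor do they show how the change behaves on any further core.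

The compounds shown leave open how other groups on that aromatic nitrogen would behave, such as cyclohexyl, a longer chain or a chain ending in an amine. With only a single concentration tested, they also leave open whether compound 4 would give a stronger or weaker effect at other concentrations.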